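Fluoro to chloro on the pendant phenyl of compound 2

The source may report more compounds than this note shows. Statements on the series, on what has been measured and on what is new or still open speak of the compounds shown alone.

Compound 1 `O=C(Nc1ccc(Oc2ccnc3[nH]ccc23)cc1)c1cc2cccnc2n(-c2ccccc2)c1=O` gives in a functional assay on NCI-H460 cells (Homo sapiens) for antiproliferative activity, read by MTT assay, with a stated time of 72 h (a higher number here means a weaker inhibitor, a lower number a stronger inhibitor), a value of 380 nM. Compound 2 `O=C(Nc1ccc(Oc2ccnc3[nH]ccc23)cc1)c1cc2cccnc2n(-c2ccc(F)cc2)c1=O` gives in this assay a value of 190 nM. Within the data shown here, the one measured step, a 2.0-fold lower number from compound 1 to compound 2 (0.30 log units; within the scatter), is within the scatter. Of the two numbers shown, compound 2 has the lower, but the gap to compound 1 is within the scatter, so the two cannot be told apart on these data.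

Compound 3 `O=C(Nc1ccc(Oc2ccnc3[nH]ccc23)cc1)c1cc2cccnc2n(-c2ccc(Cl)cc2)c1=O` differs from compound 2 by chloro in place of fluoro on an aromatic carbon. Among the measured compounds shown here, no measured step exchanges one halogen for another; the only step that bears on this position, a 2.0-fold lower number from compound 1 to compound 2 (0.30 log units; within the scatter), put fluoro in place of hydrogen there and stayed within the scatter. For the measured compounds named here, with that as the sole guide, a step from compound 2 to compound 3 in this assay is expected to be small, most likely none beyond the scatter, in either direction: a 1.1-fold lower number from compound 2 to compound 3 (0.02 log units; within the scatter) is the estimated step. Compound 3 is therefore expected to give about 180 nM in this assay, within an estimated range from 70 nM to 450 nM.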

Compound 3, half-maximal inhibitory concentration: 290 nM
For compound 3 the middle estimate is 1.6-fold (0.21 log units) below the measured one; low and high end bracket the measured number.
By their numbers in this assay, from the lowest: compounds 2, 3 and 1 (each within the scatter of the next).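

In this assay, among these compounds, 4-fluorophenyl to 4-chlorophenyl gives a 1.5-fold higher number from compound 2 to compound 3 (0.18 log units; within the scatter), the first direct comparison of two halogens on this aromatic carbon, para to a large group. Setting chloro against hydrogen at the same place gives a 1.3-fold lower number from compound 1 to compound 3 (0.12 log units; within the scatter), so hydrogen, fluoro and chloro now form a set of three whose steps all stay within the scatter, and none of the three can be separated from the others on these data. Nothing available explains the values or says what the exchange of one halogen for the other does beyond this read-out.

The compounds shown leave open whether any group at this position can move the number beyond the scatter, and in which direction; a methoxy group, an amine, a carboxylic acid or a longer chain would test this, since each differs from the halogens far more than they differ from one another. Also open, on these data alone, is whether the same flat reading holds for a halogen on another carbon of the phenyl ring, or outside these cells.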